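This account rests on a few compounds, and the source may have more. Where it says the series, first, only, none or still open, it means among the compounds named here.

Of the compounds shown here, three sharing one core have been tested in a functional assay on Cortical neurone cells (Rattus norvegicus, strain Sprague-Dawley), read by MTT assay, with stated times of 24 h and 2 h, tested at 10 uM; on this read-out lower numbers stand for a weaker effect and higher numbers for a stronger effect at the one concentration tested. Compound 1 `COC(=O)C1=CNC(=O)[C@@H]2C(CO)=CC[C@H]12` gives 79.3%. Compound 2 `COC(=O)C1=CN(C(C)C)C(=O)[C@@H]2C(CN3CCN(Cc4cccc(C(F)(F)F)c4)CC3)=CC[C@H]12`, which carries a substituted piperazine side chain and an isopropyl group on the ring nitrogen, gives 85.5%. Compound 3 `COC(=O)C1=CN(C)C(=O)[C@@H]2C(CN3CCN(Cc4cccc(C(F)(F)F)c4)CC3)=CC[C@H]12` gives 80.3%. Compound 2 holds the top number of the three, but only nominally: a number 5.2 percentage points lower from compound 2 to compound 3 (within the scatter), and its gap to compound 1 is likewise within the scatter, so the three readings cannot be told apart.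

Compound 4 `COC(=O)C1=CN(C(C)C)C(=O)[C@@H]2C(CN3CCN(Cc4cccc(OC)c4)CC3)=CC[C@H]12` has not yet been measured. It differs from compound 2 in one place: methoxy in place of trifluoromethyl on an aromatic carbon. Going by the values given here, no measured pair changes this part of the molecule, so nothing directly tells how this assay responds to it. Among the compounds with values here, the only measured step, from compound 2 to compound 3, lies elsewhere and is within the scatter. Compound 4 is therefore expected to stay close to compound 2, with a number 3.5 percentage points lower from compound 2 to compound 4 (within the scatter) not reaching beyond the scatter. The estimate for compound 4 in this assay is 82%, between 70% and 92%.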

Compound 4, a percentage reported as activity, at one concentration (the size of the read-out at that concentration, not a potency): 64%
Beside the measured number, compound 4's estimate is 18 percentage points above it, outside the stated range (below it).
By their numbers in this assay, from the lowest: compound 4; then compounds 1, 3 and 2 (each within the scatter of the next).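

In this assay, the group on the aromatic ring of the side chain proves to matter: replacing trifluoromethyl with methoxy, which turns 3-(trifluoromethyl)benzyl into 3-methoxybenzyl, gives a number 21.5 percentage points lower from compound 2 to compound 4 (beyond the scatter) at this single concentration. Going by these compounds alone, the earlier step at the ring nitrogen, a number 5.2 percentage points lower from compound 2 to compound 3 (within the scatter), did not separate its two compounds, so this is the first change to shift the reading by more than the usual scatter. No measurement shown here explains why this swap lowers the number.

The compounds shown leave open whether a hydrogen, a chlorine or a nitrile at the same place would read like compound 2 or like compound 4. They also leave open whether methoxy would lower the number similarly with the methyl on the ring nitrogen of compound 3.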